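The source may report more compounds than this note shows. Statements on the series, on what has been measured and on what is new or still open speak of the compounds shown alone.

Working notes on the series.

Of the compounds shown here, two share the core and have been measured in an assay on membranes from HEK293 cells for displacement of a labelled ligand from adenosine receptor A2b (Homo sapiens), read by scintillation counting, with a stated time of 30 min, tested at 1 uM; on this read-out higher numbers stand for more inhibition at the one concentration tested (going by the name of the read-out) and lower numbers for less inhibition. Compound 1 `CCN(CC)C(=O)C1=C(C)NC(=O)NC1c1ccsc1` gives 11%. Compound 2 `CCSC(=O)C1=C(C)NC(=O)NC1c1cccs1` gives 1%. Compound 2 carries the lower of the two numbers, yet against compound 1 the gap lies within the scatter, so on these numbers the inhibition of neither compound can be called higher or lower than that of the other; both sit close to the floor of this assay. Within the data shown here, no pair differing in a single place has been measured, so the effect of any one change on the core is unknown here.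

Compound 3 `CCSC(=O)C1=C(C)NC(=O)NC1c1ccsc1` has the same atoms as compound 2, joined differently: thiophen-3-yl in place of thiophen-2-yl on a saturated ring carbon. Among the measured compounds shown here, the pair compound 2 and compound 3 is the only single-place comparison available, and it has no measured counterpart. Given that both measured compounds sit near the floor, the step in this assay is expected to be small and in no particular direction, none beyond the scatter. Compound 3 is estimated at 5%, with a range from -10% to 20%, because compound 2 gives 1% and the expected step from compound 2 to compound 3 is a number 4 percentage points higher from compound 2 to compound 3 (within the scatter).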

Compound 3, a percentage reported as inhibition, at one concentration (the size of the read-out at that concentration, not a potency): 17%
The estimate for compound 3 lay 12 percentage points below the measured number, and the stated range covers the measured number.
By their numbers in this assay, from the lowest: compounds 2, 1 and 3 (each within the scatter of the next, the first and the last beyond it).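

In this assay the first single-place comparison gives a number 16 percentage points higher from compound 2 to compound 3 (beyond the scatter), so moving the attachment point of the thiophene, with the same atoms, registers on this read-out, although the step is modest and a single concentration says nothing about potency. With thiophen-3-yl held in place on the saturated ring carbon, ethylsulfanyl in place of diethylamino on the carbonyl carbon gives a number 6 percentage points higher from compound 1 to compound 3 (within the scatter), so these two groups cannot be told apart at this position on these numbers. Nothing at hand accounts for the step between the two thiophene isomers.

From the compounds shown here alone, whether the thiophene step carries over to compounds with diethylamino on the carbonyl carbon remains open, since only the ethylsulfanyl pair can be read. Also open, going by these compounds, is how a phenyl ring or a furan-3-yl group would compare with thiophen-3-yl on the saturated ring carbon, and how a carboxylic acid or a longer thioester chain would compare with ethylsulfanyl on the carbonyl carbon.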